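Fluoro addition on the aryl ring of the aminothiophene ester series

The source may report more compounds than this note shows. Statements on the series, on what has been measured and on what is new or still open speak of the compounds shown alone.

Measured so far:
Compound 1 `CCOC(=O)c1c(-c2ccc(OC)cc2F)csc1N`: 100%
Compound 2 `COc1cccc(-c2csc(N)c2C(=O)OCc2ccccc2)c1`: 57%
Compound 3 `COc1ccc(-c2csc(N)c2C(=O)OCc2ccccc2)cc1`: 86%

In an assay on isolated protein for inhibition of protein kinase C zeta type (Homo sapiens), with stated times of 1 h and 2.5 min, tested at 30 uM (on this read-out lower numbers stand for less inhibition and higher numbers for more inhibition at the one concentration tested (going by the name of the read-out)), compound 3 gives 86%, the second highest of the three numbers. The nearest value is that of compound 1 100%, above it beyond the scatter; the furthest is that of compound 2 57%, below it beyond the scatter. For the measured compounds named here, the one measured single-place step, a number 29 percentage points higher from compound 2 to compound 3 (beyond the scatter), concerns the methoxy position and is modest.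

Compound 4 `COc1ccc(-c2csc(N)c2C(=O)OCc2ccccc2)c(F)c1` differs from compound 3 by fluoro in place of hydrogen on an aromatic carbon. Going by the values given here, no measured step covers fluoro in place of hydrogen; compound 1 carries this fluoro together with a different ester and differs from compound 3 in two places, so only the two values can be compared, and compound 1 sits higher. With compound 3 already near the top of this read-out, the expected step of a number 7 percentage points higher from compound 3 to compound 4 (within the scatter) in this assay is small and upward, most of it within the scatter. Compound 4 is therefore estimated at 93%, in the range 78% to 100%.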

Compound 4, a percentage reported as inhibition, at one concentration (the size of the read-out at that concentration, not a potency): 78%
Beside the measured number, compound 4's estimate is 15 percentage points above it, and the stated range covers the measured number.
By their numbers in this assay, from the lowest: compound 2; then compounds 4 and 3 (each within the scatter of the next); then compound 1.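

In this assay, fluoro in place of hydrogen on an aromatic carbon, ortho to a large group and meta to a methoxy group, gives a number 8 percentage points lower from compound 3 to compound 4 (within the scatter), so this change at this place has no readable effect on the number. With the fluoro held constant, the ester can now be read by itself: phenyl in place of methyl on the saturated chain carbon bound to an oxygen next to a carbonyl group gives a number 22 percentage points lower from compound 1 to compound 4 (beyond the scatter), a step beyond the scatter that rests on this one pair. Nothing measured accounts for either step.

Open, going by these compounds, is whether fluoro also leaves the number unchanged alongside the ester of compound 1. Also open, on these data alone, is how a chlorine at this place, or an amide in place of the ester, would read in this assay.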